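This account rests on a few compounds, and the source may have more. Where it says the series, first, only, none or still open, it means among the compounds named here.

In a functional assay on cells (T-cell line, Homo sapiens) for inhibition (a lower number here means a stronger inhibitor, a higher number a weaker inhibitor), the measured compounds are:

Compound 1 `CCN1CCC(COC(c2ccccc2)c2ccccc2)CC1`: > 20000 nM, a limit of the assay
Compound 2 `CCCN1CCC(COC(c2ccccc2)c2ccccc2)CC1`: 17800 nM
Compound 3 `CCCCCCN1CCC(COC(c2ccccc2)c2ccccc2)CC1`: 5500 nM

Compound 3, at 5500 nM, has the lowest number of the series and is the strongest inhibitor shown. Compound 2 follows at 17800 nM. Compound 1 gives only a limit.

Compound 4 `COc1ccc(/C=C/CN2CCC(COC(c3ccccc3)c3ccccc3)CC2)cc1` carries 2-(4-methoxyphenyl)ethenyl in place of pentyl on a saturated chain carbon bound to an amine nitrogen in a ring.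

The nearest evidence comes from the chain changes at this same nitrogen substituent. The step of a 3.2-fold lower number from compound 2 to compound 3 (0.51 log units; beyond the scatter) is modest, and an at least 3.6-fold lower number from compound 1 to compound 3 (0.56 log units; beyond the scatter) is at least modest, whereas an at least 1.1-fold lower number from compound 1 to compound 2 (0.05 log units; that floor lies within the scatter) gives only a floor. Across these three compounds, the longer chains go with lower numbers, and no compound among them goes against this. None of them, however, carries an aromatic ring in this substituent, so they bear on compound 4 only indirectly.

A small further fall in this assay is therefore expected, with considerable uncertainty. The expected step is a 2.2-fold lower number from compound 3 to compound 4 (0.34 log units; beyond the scatter). For compound 4, the estimated value is 2500 nM, with an expected range of 500 nM to 10000 nM.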

Compound 4, half-maximal inhibitory concentration: 4300 nM
Estimate against measurement, compound 4: 1.7-fold (0.24 log units) below; low and high end bracket the measured number.
By their numbers in this assay, from the lowest: compounds 4 and 3 (each within the scatter of the next); then compound 2. At a limit, above all of these: compound 1.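

In this assay, within the data shown here, 2-(4-methoxyphenyl)ethenyl in place of pentyl gives a 1.3-fold lower number from compound 3 to compound 4 (0.11 log units; within the scatter), so a substituent with an aromatic ring, which none of the earlier compounds carried at this nitrogen, cannot be told apart from the purely aliphatic chain of compound 3. Against the shorter chains the same group stands clear, with a 4.1-fold lower number from compound 2 to compound 4 (0.62 log units; beyond the scatter) and an at least 4.6-fold lower number from compound 1 to compound 4 (0.66 log units; beyond the scatter), which shows that a low number in this series does not depend on a plain saturated chain at this place, although compound 4 adds nothing measurable beyond compound 3. The step from compound 1 is only a floor, since compound 1 stands at a limit of the assay: the limit of > 20000 nM in this assay, at which 1 of the 4 values shown sits.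

On these data alone, whether the number of compound 4 owes anything to the methoxy group or to the double bond stays open, and a plain phenyl or a saturated phenylpropyl chain in this place would be the comparison that separates them. Equally open, as far as these compounds go, is how a longer chain than that of compound 3, or a substituent carrying an amine or a carboxylic acid in this place, would read in this assay.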